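Swapping the Aryl Group on the Carbonyl Carbon

This account rests on a few compounds, and the source may have more. Where it says the series, first, only, none or still open, it means among the compounds named here.

Measured so far:
Compound 1 `COc1cc(-c2cc(/C=C/C(=O)c3ccc(Cl)c(Cl)c3)[nH]n2)cc(OC)c1OC`: -36%
Compound 2 `COc1ccc(C(=O)/C=C/c2cc(-c3cc(OC)c(OC)c(OC)c3)n[nH]2)cc1`: -9%

Of the compounds shown here, two that share one core have been tested in a functional assay on T47D cells (Homo sapiens) for cytotoxicity, read by sulforhodamine B assay, with a stated time of 48 h, tested at 100 uM; a lower number here means a stronger effect, a higher number a weaker effect of the compound at the concentration tested. Compound 1 gives -36% in this assay. Compound 2 gives -9% in this assay, the higher of the two numbers, meaning the weaker effect at the concentration tested. The only difference between them lies on the carbonyl carbon, and the step there was a number 27 percentage points higher from compound 1 to compound 2 (beyond the scatter).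

Compound 3 `COc1cc(-c2cc(/C=C/C(=O)c3ccc(F)c(F)c3)[nH]n2)cc(OC)c1OC` has not yet been measured. It differs from compound 2 only at that same carbonyl carbon: 3,4-difluorophenyl in place of 4-methoxyphenyl on a carbonyl carbon. Among the measured compounds shown here, the one measured step bears on this change directly, since it shows that removing the dichlorophenyl from that position in favour of methoxyphenyl raised the number by a number 27 percentage points higher from compound 1 to compound 2 (beyond the scatter). Putting a halogenated ring back in that position is therefore expected to move the number back down, though fluorine is not chlorine and the size is uncertain. The expected step is a number 16 percentage points lower from compound 2 to compound 3 (beyond the scatter). For compound 3 the estimate in this assay is -25%, with a range from -45% to 0%.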

Compound 3, a percentage reported as activity, at one concentration (the size of the read-out at that concentration, not a potency): -11%
For compound 3 the middle estimate is 14 percentage points below the measured one; the range from low to high includes it.
By their numbers in this assay, from the lowest: compound 1; then compounds 3 and 2 (each within the scatter of the next).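

Read in this assay, placing 3,4-difluorophenyl where 4-methoxyphenyl stood on the carbonyl carbon gives a number 2 percentage points lower from compound 2 to compound 3 (within the scatter), so a halogen-bearing ring at this position does not by itself restore the stronger effect seen for compound 1. The two halogenated rings do differ: 3,4-difluorophenyl in place of 3,4-dichlorophenyl gives a number 25 percentage points higher from compound 1 to compound 3 (beyond the scatter), which leaves the dichlorophenyl ring standing apart among these three compounds, while compound 2 and compound 3 lie within the scatter of each other. Nothing available explains why the chlorine-bearing ring separates from the fluorine-bearing one.

These three rings leave open whether a single chlorine, as in 4-chlorophenyl, or bromine, as in 3,4-dibromophenyl, would read like 3,4-dichlorophenyl. Also open, from the compounds shown here alone, is how a phenyl ring carrying an amine or a carboxylic acid would read on this carbonyl carbon, and, with every number taken at one concentration, whether the stronger and weaker effects seen at that concentration would hold at any other.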